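Swapping Amino for Nitro on a Second Core

The source may hold more compounds than are shown below. What is called first, only, known or untested is meant among the compounds shown, and "the series" means these compounds.

Compound 1 `COc1ccc2c(/C=C/C(=O)c3cc(N)c(OC)c(OC)c3)c[nH]c2c1` and compound 2 `COc1ccc2c(/C=C/C(=O)c3cc(OC)c(OC)c([N+](=O)[O-])c3)c[nH]c2c1` differ in one place: nitro in place of amino on an aromatic carbon. In a functional assay on MCF7 cells (Homo sapiens) for antiproliferative activity, read by MTT assay, with a stated time of 48 h (a lower number here means a stronger inhibitor, a higher number a weaker inhibitor), compound 1 gives 249 nM, while compound 2 gives 662 nM, so this change made a 2.7-fold higher number from compound 1 to compound 2 (0.42 log units; beyond the scatter). Compound 3 `COc1cc(C(=O)/C=C/c2cn(C)c3ccccc23)cc(N)c1OC` is built on a different core; the difference between the two cores is not broken down here. In this assay compound 3 gives 631 nM, which lies within the scatter of compound 2 and beyond the scatter from compound 1. Compound 4 `COc1cc(C(=O)/C=C/c2cn(C)c3ccccc23)cc([N+](=O)[O-])c1OC` has not yet been measured. It differs from compound 3 by the same change: nitro in place of amino on an aromatic carbon. Among the compounds with values here, the one earlier instance of this change gave a 2.7-fold higher number from compound 1 to compound 2 (0.42 log units; beyond the scatter). A step of similar size is expected from the same change here, a 2.7-fold higher number from compound 3 to compound 4 (0.43 log units; beyond the scatter), though it rests on a single example. Compound 4 is therefore estimated at 1700 nM in this assay, expected to fall between 800 nM and 3600 nM.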

Compound 4, half-maximal inhibitory concentration: 1770 nM
Compound 4: the middle estimate sits 1.0-fold (0.02 log units) below what was measured; measured number inside the range.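

Putting nitro in place of amino on the core of compound 3 gave a 2.8-fold higher number from compound 3 to compound 4 (0.45 log units; beyond the scatter) in this assay. Set beside the earlier case, the step carried over to the second core with much the same size: the same change on two cores in this assay, a 2.7-fold higher number (0.42 log units; beyond the scatter) from compound 1 to compound 2 and a 2.8-fold higher number (0.45 log units; beyond the scatter) from compound 3 to compound 4, 1.1-fold (0.02 log units) apart, within the scatter of two such steps. This shows that the change behaved alike on these two cores in this one assay, but two examples do not show that it would do so on a third core, and they do not explain why nitro gives the higher number.

Still open, on these data alone, is how other groups on the same aromatic carbon would compare with amino and nitro, such as a nitrile, an acetamide or a methylamino group. As far as these compounds go, whether the step holds in other cell lines also remains unknown.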